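Aryl triazole series: moving the methoxy group on the phenyl

A few compounds are considered here, and "the series" means these few. Any claim that something is new, unique, unknown or untested is made for them only; others in the source may bear on it.

Compound 2 `COc1ccccc1-n1cc(CN2C(=O)C[C@@H]3CC[C@@]2(C)C3(C)C)nn1` stands level with compound 1 `CC1(C)[C@H]2CC[C@]1(C)N(Cc1cn(-c3ccccc3Br)nn1)C(=O)C2` at the lowest of the three numbers recorded. In a functional assay on OVCAR-3 cells (Homo sapiens) for inhibition, read by MTT assay, with a stated time of 24 h (a higher number here means a weaker inhibitor, a lower number a stronger inhibitor), compound 2 gives 140 nM and compound 1 gives 140 nM; compound 3 `CC1(C)[C@H]2CC[C@]1(C)N(Cc1cn(-c3ccc(Cl)cc3)nn1)C(=O)C2` gives 160 nM in this assay. Every measured step in this set stays inside the scatter: no change at the digits printed from compound 1 to compound 2 (within the scatter), a 1.1-fold higher number from compound 2 to compound 3 (0.06 log units; within the scatter) and a 1.1-fold higher number from compound 1 to compound 3 (0.06 log units; within the scatter).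

Compound 4 `COc1cccc(-n2cc(CN3C(=O)C[C@@H]4CC[C@@]3(C)C4(C)C)nn2)c1` is built from compound 2 by a single change on the aryl group attached to the aromatic nitrogen: 3-methoxyphenyl in place of 2-methoxyphenyl on an aromatic nitrogen. All three measured steps concern the same aryl group, covering methoxy in place of bromo and 4-chlorophenyl in place of either 2-bromophenyl or 2-methoxyphenyl, and none of them shifted the number beyond the scatter in this assay. On that basis no step beyond the scatter is expected for moving the methoxy group either. The expected step is a 1.1-fold higher number from compound 2 to compound 4 (0.03 log units; within the scatter). Compound 4 is therefore estimated to give 150 nM in this assay, with a range from 75 nM to 300 nM.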

Compound 4, half-maximal inhibitory concentration: 280 nM
Beside the measured number, compound 4's estimate is 1.9-fold (0.27 log units) below it; the range from low to high includes it.
By their numbers in this assay, from the lowest: compounds 1, 2, 3 and 4 (each within the scatter of the next).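

Working from the 2-methoxyphenyl compound in this assay, moving the methoxy group to give 3-methoxyphenyl produces a 2.0-fold higher number from compound 2 to compound 4 (0.30 log units; within the scatter) and so remains within the scatter, even though this is the first change in the set that keeps the atoms of the aryl group and alters only their placement. Within the data shown here, the other two new steps, a 2.0-fold higher number from compound 1 to compound 4 (0.30 log units; within the scatter) and a 1.8-fold higher number from compound 3 to compound 4 (0.24 log units; within the scatter) also within the scatter, extend the same reading: across all four aryl groups on the aromatic nitrogen, no step in this assay lies beyond the scatter. No measured property in hand bears on these steps.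

Whether 4-methoxyphenyl would also stay within the scatter of these compounds remains open. So does the effect in this assay of an amine or a carboxylic acid on the phenyl, or of a longer chain in place of the methoxy group.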